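Clearance Expectation for a Swap on the Amide Side Chain

The source may report more compounds than this note shows. Statements on the series, on what has been measured and on what is new or still open speak of the compounds shown alone.

Compound 1 `COc1cc(N2CCN(C(=O)CN3Cc4ccccc4C3)CC2)ccc1-c1cnc(C)o1` was run in an ADME assay on microsomes from liver (Rattus norvegicus) for metabolic stability, read by LC-MS (on this read-out higher numbers stand for fast clearance and lower numbers for slow clearance), where compound 1 gives 42 mL.min-1.g-1. Compound 2 `COc1cc(N2CCN(C(=O)Cn3cnc4ccc(C(F)(F)F)cc43)C[C@@H]2C)ccc1-c1cnc(C)o1` sits alongside it: in this assay compound 2 gives 50 mL.min-1.g-1, a gap within the usual scatter, so neither stands apart. Compound 3 `COc1cc(N2CCN(C(=O)Cn3nnc4ccccc43)CC2)ccc1-c1cnc(C)o1` has not yet been measured. It differs from compound 1 by a group of 9 heavy atoms (6 carbon, 3 nitrogen; one five-membered aromatic ring with 3 hetero atoms, one six-membered aromatic ring of carbon only) in place of a group of 9 heavy atoms (8 carbon, 1 nitrogen; one five-membered non-aromatic ring with 1 hetero atom, one six-membered aromatic ring of carbon only), on a saturated chain carbon bound to a carbonyl carbon. Going by the values given here, no measured step of this kind exists to lean on, so the expected step of a 1.3-fold lower number from compound 1 to compound 3 (0.12 log units; within the scatter) is small, leaning toward a lower number without clearly passing beyond the scatter. Compound 3 is therefore expected to give 32 mL.min-1.g-1, most likely between 15 mL.min-1.g-1 and 70 mL.min-1.g-1.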

Compound 3, intrinsic clearance in microsomes: 27 mL.min-1.g-1
Estimate against measurement, compound 3: 1.2-fold (0.07 log units) above; the measured number falls inside the stated range.
By their numbers in this assay, from the lowest: compounds 3, 1 and 2 (each within the scatter of the next).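

In this assay, the swap on the saturated chain carbon bound to a carbonyl carbon gives a 1.6-fold lower number from compound 1 to compound 3 (0.19 log units; within the scatter) and so shows that this position accepts a five-membered aromatic ring with 3 hetero atoms in place of a five-membered non-aromatic ring with 1 hetero atom, with the read-out staying within the scatter. Nothing measured here accounts for this small step. Still open, from the compounds shown here alone, is whether a different group on the same carbon, such as a simple amine or a carboxylic acid, would give a step beyond the scatter.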